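From 4-fluorobenzyl to 3-(trifluoromethyl)benzyl in a level series

The source may report more compounds than this note shows. Statements on the series, on what has been measured and on what is new or still open speak of the compounds shown alone.

In a functional assay on THP-1 cells (Homo sapiens) for inhibition (on this read-out higher numbers stand for weaker inhibition of growth and lower numbers for stronger inhibition of growth), compound 1 `Cc1noc(C)c1-c1ccc2c(c1)c(Cc1ccccc1)cn2CCCCCCC(=O)NO` gives 15500 nM and compound 3 `Cc1ccccc1Cc1cn(CCCCCCC(=O)NO)c2ccc(-c3c(C)noc3C)cc12` gives 15500 nM on the same scale. Compound 2 `Cc1noc(C)c1-c1ccc2c(c1)c(Cc1ccc(F)cc1)cn2CCCCCC(=O)NO` stands level with both, at 15500 nM in the same read-out, so the starting point for this step is neither above nor below its neighbours.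

The next molecule, compound 4 `Cc1noc(C)c1-c1ccc2c(c1)c(Cc1cccc(C(F)(F)F)c1)cn2CCCCCC(=O)NO`, has not been measured yet. It differs from compound 2 in one piece, on a saturated chain carbon bound to an aromatic carbon: 3-(trifluoromethyl)phenyl in place of 4-fluorophenyl on a saturated chain carbon bound to an aromatic carbon and the same difference also reads 4-fluorobenzyl to 3-(trifluoromethyl)benzyl.

Among the compounds with values here, only one measured step bears on this, and only loosely. With a methyl in place of hydrogen on an aromatic carbon, the data show no change at the digits printed from compound 1 to compound 3 (within the scatter) as the whole effect. Within the data shown here, no measured pair tests a trifluoromethyl group directly, so this evidence is thin. Even so, nothing measured so far points to a shift in either direction in this assay for compound 4.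

The estimated step is no change at the digits printed from compound 2 to compound 4 (within the scatter) and so no change beyond the scatter is expected. For compound 4 the estimated value is 15500 nM with an expected range from 7000 nM to 30000 nM as the likely span.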

Compound 4, concentration for 50% growth inhibition: 15500 nM
Estimate against measurement, compound 4: no gap at the digits printed, within the range that was stated.
By their numbers in this assay, from the lowest: compounds 1, 2, 3 and 4 (each within the scatter of the next).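

In this assay, replacing 4-fluorophenyl with 3-(trifluoromethyl)phenyl on a saturated chain carbon bound to an aromatic carbon gives no change at the digits printed from compound 2 to compound 4 (within the scatter). The earlier step at this place in the molecule was only a methyl in place of hydrogen, whereas this one swaps the whole aryl group, with 10 heavy atoms entering where 7 leave and 3 fluorines in place of 1, and the read-out still does not respond beyond the scatter. No measurement available here explains why the value stays flat through this change.

With every compound shown at the same printed value, nothing yet reveals which kind of group at this place could move growth inhibition in either direction, or whether any could. An amine or a carboxylic acid on the benzyl ring, or a pyridine ring in place of the phenyl ring, would test this place with groups unlike the hydrogen, methyl, fluorine and trifluoromethyl variants shown so far.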